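A few compounds are considered here, and "the series" means these few. Any claim that something is new, unique, unknown or untested is made for them only; others in the source may bear on it.

Measured so far in an assay on isolated protein for inhibition of Polyunsaturated fatty acid 5-lipoxygenase (Rattus norvegicus); a higher number here means a weaker inhibitor, a lower number a stronger inhibitor:
compound 1 `COC(=O)CCC(=O)Nc1cccc(OCc2ccc3ccccc3n2)c1`: 28000 nM
compound 2 `COC(=O)CCC(=O)Nc1cc(OCc2ccc3ccccc3n2)ccc1C`: 7600 nM

Compound 1 stands highest of the two numbers in this assay; the nearest is compound 2, reached by a 3.7-fold lower number from compound 1 to compound 2 (0.57 log units; beyond the scatter). Compound 3 `COC(=O)CCC(=O)N(C)c1cccc(OCc2ccc3ccccc3n2)c1` differs from compound 1 by methyl in place of hydrogen on an amide-type nitrogen. Going by the values given here, the only measured step, from compound 1 to compound 2, concerns a methyl on an aromatic carbon, not the amide-type nitrogen, so it bears only loosely on this change; no measured pair shows what a methyl on that nitrogen does. For compound 3 the expectation is therefore a step not beyond the scatter, a 1.1-fold higher number from compound 1 to compound 3 (0.03 log units; within the scatter), with wide uncertainty. Compound 3 is estimated at 30000 nM, in the range 8000 nM to 100000 nM.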

Compound 3, half-maximal inhibitory concentration: 14000 nM
Compound 3: the middle estimate sits 2.1-fold (0.33 log units) above what was measured; the measured number falls inside the stated range.
By their numbers in this assay, from the lowest: compounds 2, 3 and 1 (each within the scatter of the next, the first and the last beyond it).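

In this assay, methyl in place of hydrogen on the amide-type nitrogen gives a step that stays within the scatter (a 2.0-fold lower number from compound 1 to compound 3 (0.30 log units; within the scatter)). The amide hydrogen is therefore not needed to hold inhibition at the level of compound 1, and this methyl adds no gain that can be separated from the scatter. No measurement at hand bears on the reason for this step.

Open, as far as these compounds go, is whether an ethyl or a longer chain on that nitrogen is tolerated in the same way. Also open, from the compounds shown here alone, is how a carboxylic acid in place of the methyl ester reads.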